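The source may hold more compounds than are shown below. What is called first, only, known or untested is meant among the compounds shown, and "the series" means these compounds.

Compound 1 `O=C(Nc1cccc(-n2cc(-c3ccncc3)c(-c3ccc(Cl)c(O)c3)n2)c1)Nc1ccc(Cl)c(Cl)c1`: 16100 nM
Compound 3 `O=C(Nc1cccc(-n2cc(-c3ccncc3)c(-c3ccc(Cl)c(O)c3)n2)c1)Nc1ccc(Cl)c(C(F)(F)F)c1`: 8070 nM
Compound 2 `COc1cc(-c2nn(-c3cccc(NC(=O)c4ccccc4)c3)cc2-c2ccncc2)ccc1Cl`: > 100000 nM, a limit of the assay

All three were tested in a functional assay on BT-549 cells (Homo sapiens) for inhibition, read by sulforhodamine B assay, with a stated time of 48 h; a higher number here means a weaker inhibitor of growth, a lower number a stronger inhibitor of growth. Compound 1 has the highest of the two plain numbers, and the step of a 2.0-fold lower number from compound 1 to compound 3 (0.30 log units; within the scatter) lies within the scatter. For compound 2 the value is only a limit (the limit of > 100000 nM in this assay, at which 1 of the 3 values shown sits).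

Compound 4 `COc1cc(-c2nn(-c3cccc(NC(=O)Nc4ccc(Cl)c(Cl)c4)c3)cc2-c2ccncc2)ccc1Cl` differs from compound 1 by methyl in place of hydrogen on an oxygen on an aromatic ring. For the measured compounds named here, no measured step touches this oxygen; the single measured step, a 2.0-fold lower number from compound 1 to compound 3 (0.30 log units; within the scatter), concerns another ring. Compound 2, which also carries the 4-chloro-3-methoxyphenyl group but a benzamide instead of the urea, shows only a limit. A rise in the number is therefore expected for compound 4, namely a 2.5-fold higher number from compound 1 to compound 4 (0.40 log units; beyond the scatter). Compound 4 is estimated at 40000 nM, with a range from 12000 nM to 100000 nM.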

Compound 4, concentration for total growth inhibition: 27600 nM
Compound 4: middle estimate off by 1.4-fold (0.16 log units), on the high side, and the stated range covers the measured number.
By their numbers in this assay, from the lowest: compounds 3, 1 and 4 (each within the scatter of the next, the first and the last beyond it). At a limit, above all of these: compound 2.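

In this assay, methoxy in place of hydroxy on the 4-chloro-3-hydroxyphenyl group gives a 1.7-fold higher number from compound 1 to compound 4 (0.23 log units; within the scatter), so this change does not clearly separate the two compounds. Compound 2 also carries methoxy, and its value is a limit: the limit of > 100000 nM in this assay, at which 1 of the 4 values shown sits. With (3,4-dichlorophenyl)amino in place of phenyl on the carbonyl carbon, the data show an at least 3.6-fold lower number from compound 2 to compound 4 (0.55 log units; beyond the scatter), so the methoxy group can give a measurable number when the urea is present.

From the compounds shown here alone, whether ethoxy or an amine at this position would shift the number remains open. So does whether the trifluoromethyl group of compound 3 would give a similar number alongside methoxy.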